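Para-fluoro on the benzamide of compound 2

The compounds below may be only part of what the source reports. "The series", "measured", "known", "first", "only" and "open" are said of these compounds alone.

Measured compounds:
compound 1 `COc1cccc(-c2nn(-c3ccccc3)cc2-c2ccnc(NCCNC(=O)Nc3cccc(C(F)(F)F)c3)c2)c1` 3550 nM
compound 2 `O=C(NCCCNc1cc(-c2cn(-c3ccccc3)nc2-c2cccc(O)c2)ccn1)c1ccccc1` 3120 nM

In a functional assay on SK-MEL-5 cells (Homo sapiens) for inhibition (a lower number here means a stronger inhibitor of growth, a higher number a weaker inhibitor of growth), compound 1 gives 3550 nM and compound 2 gives 3120 nM. The two numbers lie within the scatter of each other, so neither compound can be called the stronger inhibitor on this evidence; compound 2 simply sits alongside compound 1.

Compound 3 `O=C(NCCCNc1cc(-c2cn(-c3ccccc3)nc2-c2cccc(O)c2)ccn1)c1ccc(F)cc1` has not yet been measured. It differs from compound 2 in one place: fluoro in place of hydrogen on an aromatic carbon. The fluoro enters on the benzamide ring, para to the large group, and nothing else in the molecule moves.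

Within the data shown here, no step between measured compounds covers this kind of change, so there is no in-series precedent to lean on. The expectation is for a step in this assay that stays within the scatter, with no clear direction, giving a 1.1-fold lower number from compound 2 to compound 3 (0.05 log units; within the scatter). Compound 3 is therefore estimated at 2800 nM, with a range from 1200 nM to 7000 nM.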

Compound 3, concentration for total growth inhibition: 3150 nM
Compound 3: the middle estimate sits 1.1-fold (0.05 log units) below what was measured, within the range that was stated.
By their numbers in this assay, from the lowest: compounds 2, 3 and 1 (each within the scatter of the next).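

In this assay, among these compounds, fluoro in place of hydrogen on the benzamide ring gives a 1.0-fold higher number from compound 2 to compound 3 (0.00 log units; within the scatter), the first step that changes a single place. At this aromatic carbon, para to a large group, 4-fluorophenyl can therefore stand in for phenyl with no readable change in growth inhibition, although this one step says nothing about other substituents. No measurement on these compounds offers an explanation for this flat step.

Still open, from the compounds shown here alone, is whether an amine or a carboxylic acid on the same carbon would leave the number equally undisturbed. Also open, going by these compounds, is whether a longer chain between the amide and the shared core, or a methoxy in place of the phenol hydroxyl with the benzamide retained, would move the value beyond the scatter.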